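A few compounds are considered here, and "the series" means these few. Any claim that something is new, unique, unknown or untested is made for them only; others in the source may bear on it.

Compound 1 `O=C(NCc1cc(Cl)ccc1-n1cnnn1)[C@@H]1C[C@@H]2C[C@@H]2N1C(=O)[C@H](O)Cc1ccccn1` is one of three compounds from the same series with a number in an ADME assay on Caco-2 cells (Homo sapiens) for permeability, read by LC-MS, in the apical to basolateral direction, with a stated time of 60 min, at pH 6.5; on this read-out higher numbers stand for higher permeability and lower numbers for lower permeability. In this assay compound 1 gives 1.2 10^-6 cm/s, the lowest of the three. Compound 2 `CC(C)(C)C[C@@H](O)C(=O)N1[C@@H]2C[C@@H]2C[C@H]1C(=O)NCc1cc(Cl)ccc1-n1cnnn1` gives 24 10^-6 cm/s in this assay, and compound 3 `O=C(NCc1cc(Cl)ccc1-n1cnnn1)[C@@H]1[C@H]2C[C@H]2CN1C(=O)[C@H](O)C1CCCCC1` gives 25 10^-6 cm/s, so compound 1 sits far below both, with each gap well beyond the scatter. For the measured compounds named here, no single-point step between two measured compounds is available, and the two higher compounds differ from compound 1 in more than one place.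

Compound 4 `O=C(NCc1cc(Cl)ccc1-n1cnnn1)[C@@H]1C[C@@H]2C[C@@H]2N1C(=O)[C@H](O)C1CCCCC1` differs from compound 1 in one place: cyclohexyl in place of (pyridin-2-yl)methyl on a saturated chain carbon bound to a carbonyl carbon and an oxygen on a saturated carbon. The group that enters is the same cyclohexyl that compound 3 carries on the same kind of carbon, though compound 3 has a different arrangement of the shared core. Compound 4 is expected to move strongly upward in this assay, with an estimated step of a 15-fold higher number from compound 1 to compound 4 (1.18 log units; beyond the scatter), because compound 3 gives 25 10^-6 cm/s and compound 2 gives 24 10^-6 cm/s. Compound 4 is therefore estimated at 18 10^-6 cm/s, within a range from 7 10^-6 cm/s to 35 10^-6 cm/s.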

Compound 4, apparent permeability: 16 10^-6 cm/s
Compound 4: the middle estimate sits 1.1-fold (0.05 log units) above what was measured; low and high end bracket the measured number.
By their numbers in this assay, from the lowest: compound 1; then compounds 4, 2 and 3 (each within the scatter of the next).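

In this assay, for the compounds shown here, cyclohexyl in place of (pyridin-2-yl)methyl on a saturated chain carbon bound to a carbonyl carbon and an oxygen on a saturated carbon gives a 13-fold higher number from compound 1 to compound 4 (1.12 log units; beyond the scatter), the first step that can be read at a single place. It shows that this place alone can carry a large change in the number with the rest of the structure held constant, although the swap changes the ring type, the ring nitrogen and the chain link all at once, so the step cannot be divided among them. No measurement shown speaks to why the number moves.

Going by these compounds, whether a benzyl group, which keeps the aromatic ring and link without the ring nitrogen, would read closer to compound 1 or to compound 4 remains open. So does the reading of a cyclohexylmethyl group, or of a cyclohexyl ring carrying an amine or a carboxylic acid, at this place.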